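Propoxy in place of the biaryl arm, potency expected to drop

This account rests on a few compounds, and the source may have more. Where it says the series, first, only, none or still open, it means among the compounds named here.

Working notes on the sulfonamide series. Compound 1 `COc1ccccc1-c1ccc(S(=O)(=O)N2CCC(N3CCC(C)CC3)CC2)cc1` is the parent of this step. Among the compounds with values here, in a functional assay on DLD-1 cells (Homo sapiens) for antiproliferative activity, read by CellTiter-Glo, with a stated time of 72 h (a lower number here means a stronger inhibitor, a higher number a weaker inhibitor), compound 1 gives 26 nM, the second highest of the three numbers measured so far. Compound 3 `COc1cc(C)c(S(=O)(=O)N2CCC(N3CCC(C)CC3)CC2)cc1C(C)C` gives 3 nM, a lower number beyond the scatter, while compound 2 `Cc1ccc(C#N)c(S(=O)(=O)N2CCC(N3CCC(C)CC3)CC2)c1` gives 285 nM, a higher number beyond the scatter. Compound 4 `CCCOc1ccc(S(=O)(=O)N2CCC(N3CCC(C)CC3)CC2)cc1` is not yet measured; it differs from compound 1 by propoxy in place of 2-methoxyphenyl on an aromatic carbon. Within the data shown here, no pair of measured compounds isolates this change, so its size is unknown from the data. The expected step is a 5.8-fold higher number from compound 1 to compound 4 (0.76 log units; beyond the scatter), toward a higher number and beyond the scatter. Compound 4 is estimated at 150 nM, with a range from 40 nM to 600 nM.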

Compound 4, half-maximal inhibitory concentration: 452 nM
The estimate for compound 4 lay 3.0-fold (0.48 log units) below the measured number, within the range that was stated.
By their numbers in this assay, from the lowest: compound 3; then compound 1; then compounds 2 and 4 (each within the scatter of the next).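

Propoxy in place of 2-methoxyphenyl, on an aromatic carbon para to a large group, gives a 17-fold higher number from compound 1 to compound 4 (1.24 log units; beyond the scatter) in this assay, the first step in the series that isolates one change. This position is therefore sensitive to the exchange of the aromatic ring for an open chain, even though the counts of hydrogen-bond donors and acceptors are the same in both groups. Nothing at hand gives a cause for this step.

From the compounds shown here alone, whether the loss follows the ring itself, the methoxy on it or the size of the group remains open. An unsubstituted phenyl or a cyclohexyl at this position would begin to separate these.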